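A few compounds are considered here, and "the series" means these few. Any claim that something is new, unique, unknown or untested is made for them only; others in the source may bear on it.

Values in a functional assay on SH-SY5Y cells (Homo sapiens) for antiproliferative activity, read by MTT assay, with a stated time of 72 h; on this read-out lower numbers stand for stronger inhibition and higher numbers for weaker inhibition:
- compound 1 `CCN(CC)CCCOc1cc2ncnc(Nc3ccc(C#N)cc3)c2cc1OC`: > 100000 nM (a limit)
- compound 2 `COc1cc2c(Nc3ccc(C#N)cc3)ncnc2cc1OCCCN1CCC(O)CC1`: > 100000 nM (a limit)
- compound 3 `COc1cc2c(Nc3ccc(C#N)cc3)ncnc2cc1OCCCN1CCC(N(C)C)CC1`: 24300 nM

Among the compounds with values here, compound 3 holds the only true number here, at 24300 nM. Compound 1 and compound 2 both stand at the limit of > 100000 nM in this assay, at which 2 of the 3 values shown sit.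

Compound 4 `COc1cc2c(Nc3ccc(C#N)cc3)ncnc2cc1OCCCN1CCC(N2CCCCC2)CC1` differs from compound 3 in one group: piperidin-1-yl in place of dimethylamino on a saturated ring carbon. In words, piperidin-1-yl takes the place of dimethylamino on a saturated ring carbon.

Within the data shown here, two measured steps bear on this change. The closer one is an at least 4.1-fold lower number from compound 2 to compound 3 (0.61 log units; beyond the scatter), with dimethylamino in place of hydroxy on that same ring carbon. The other is an at least 4.1-fold lower number from compound 1 to compound 3 (0.61 log units; beyond the scatter), with 4-(dimethylamino)piperidin-1-yl in place of diethylamino. Both start from a limit, so each gives only a minimum size. Neither tests a swap of dimethylamino itself, so only a small change is expected in this assay, leaning slightly towards a lower number and not clearly beyond the scatter. The expected step is a 1.4-fold lower number from compound 3 to compound 4 (0.13 log units; within the scatter). For compound 4 the estimated value is 18000 nM, with an expected range of 6000 nM to 60000 nM.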

Compound 4, half-maximal inhibitory concentration: 9810 nM
Compound 4: middle estimate off by 1.8-fold (0.26 log units), on the high side; measured number inside the range.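

In this assay, within the data shown here, piperidin-1-yl in place of dimethylamino on this saturated ring carbon gives a 2.5-fold lower number from compound 3 to compound 4 (0.39 log units; beyond the scatter), the first step here measured between two true numbers, and it shows that a group with more heavy atoms and a ring of its own is tolerated at this position. Measured against other groups, the new side chain gives an at least 10-fold lower number from compound 2 to compound 4 (1.00 log units; beyond the scatter) and an at least 10-fold lower number from compound 1 to compound 4 (1.00 log units; beyond the scatter). Both of those steps start from a limit and give only a minimum size: the limit of > 100000 nM in this assay, at which 2 of the 4 values shown sit.

Two true numbers cannot show whether the number keeps falling as this group grows, or whether a ring matters more than size. A pyrrolidin-1-yl or morpholin-4-yl group on the same ring carbon, or a longer chain to the oxygen on the core, remains an open question.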